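The source may report more compounds than this note shows. Statements on the series, on what has been measured and on what is new or still open speak of the compounds shown alone.

Measured compounds in an assay on a protein complex for displacement of a labelled ligand from Neuronal acetylcholine receptor; alpha3/beta2 (Rattus norvegicus), read by scintillation counting; on this read-out higher numbers stand for weaker inhibition and lower numbers for stronger inhibition:
compound 1 `c1cncc(N2CC3CC2CN3)c1` at 3.1 nM
compound 2 `COCC[C@H]1C[C@@H]1c1cncc(N2CCCNCC2)c1` at 17 nM
compound 3 `CN1CCCN(c2cncc(-c3cc(CCO)no3)c2)CC1` at 1040 nM

Among these three, compound 3 stands at the highest number in this assay. The nearest measured value is that of compound 2, and the gap to it lies beyond the scatter; the furthest is that of compound 1, also beyond the scatter. Compounds 2 and 3 differ in more than one place, so their two values can only be set side by side, not read as a single step.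

Compound 4 `OCCc1cc(-c2cncc(N3CCCNCC3)c2)on1` has not yet been measured in this assay. It differs from compound 3 by one change: hydrogen in place of methyl on an amine nitrogen in a ring. The two compounds that carry a hydrogen on a ring nitrogen of this kind, compound 1 and compound 2, both give much lower numbers than compound 3, though neither differs from compound 3 in that one place alone.

Among the compounds with values here, no measured step isolates this change, so the expectation rests on the spread of the values shown. Compound 4 is expected to give a lower number than compound 3, with a step of an 8.7-fold lower number from compound 3 to compound 4 (0.94 log units; beyond the scatter) that lies beyond the scatter. The estimate for compound 4 in this assay is 120 nM, with a range from 25 nM to 600 nM.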

Compound 4, inhibition constant: 42 nM
The estimate for compound 4 lay 2.9-fold (0.46 log units) above the measured number; measured number inside the range.
By their numbers in this assay, from the lowest: compound 1; then compound 2; then compound 4; then compound 3.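

In this assay, hydrogen in place of methyl on the amine nitrogen in the seven-membered non-aromatic ring gives a 25-fold lower number from compound 3 to compound 4 (1.39 log units; beyond the scatter), a large step beyond the scatter. Earlier, the link between a hydrogen on a ring nitrogen of this kind and a low number could only be suspected from compound 1 and compound 2, both of which differ from compound 3 in more than one place. This pair shows that, with everything else in the structure held the same, the loss of one carbon at this position is enough to produce the whole step, although no measurement shown accounts for its size.

The compounds shown leave open whether a step of this size would also appear on another core, such as that of compound 2, since only this one pair isolates the change. They also leave open how the number would move with an ethyl group, a longer chain or an acetyl group on the same nitrogen, so the reading rests on hydrogen and methyl alone.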